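Aryl exchange on the amine nitrogen: trifluoro variant

This account rests on a few compounds, and the source may have more. Where it says the series, first, only, none or still open, it means among the compounds named here.

Measured in a functional assay on DU-145 cells (Homo sapiens) for cytotoxicity, read by MTT assay, with a stated time of 48 h (a lower number here means a stronger inhibitor, a higher number a weaker inhibitor), so far:
compound 1 `Cc1ccc(S(=O)(=O)/N=C(/CCNC2=CC(=O)c3ccccc3C2=O)Nc2ccc(F)c(F)c2)cc1` — 12900 nM
compound 2 `COc1cc(N/C(CCNC2=CC(=O)c3ccccc3C2=O)=N\S(=O)(=O)c2ccc(C)cc2)cc(OC)c1OC` — 9330 nM

Compound 2 carries the lowest of the two numbers, but its nearest neighbour is compound 1 at a 1.4-fold lower number from compound 1 to compound 2 (0.14 log units; within the scatter), a gap within the scatter, so no order between the two can be claimed.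

Compound 3 `Cc1ccc(S(=O)(=O)/N=C(/CCNC2=CC(=O)c3ccccc3C2=O)Nc2cc(F)c(F)c(F)c2)cc1` is not yet measured. It differs from compound 2 in one place: 3,4,5-trifluorophenyl in place of 3,4,5-trimethoxyphenyl on an amine nitrogen. Going by the values given here, the single measured step that bears on this change is the one from compound 1 to compound 2, where the same aryl group on the amine nitrogen went from difluorophenyl to trimethoxyphenyl with a 1.4-fold lower number from compound 1 to compound 2 (0.14 log units; within the scatter), a shift within the scatter. The change to compound 3 partly reverses that exchange, returning to a fluorinated ring while adding a third fluorine, for which no measured comparison exists. On this basis the expected step from compound 2 to compound 3 in this assay is a 1.3-fold higher number from compound 2 to compound 3 (0.11 log units; within the scatter), nothing beyond the scatter. Compound 3 is therefore estimated at 12000 nM, with a range from 5000 nM to 30000 nM.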

Compound 3, half-maximal inhibitory concentration: 12600 nM
Compound 3: the middle estimate sits 1.1-fold (0.02 log units) below what was measured; the range from low to high includes it.
By their numbers in this assay, from the lowest: compounds 2, 3 and 1 (each within the scatter of the next).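

In this assay, the exchange of 3,4,5-trimethoxyphenyl for 3,4,5-trifluorophenyl on the amine nitrogen gives a 1.4-fold higher number from compound 2 to compound 3 (0.13 log units; within the scatter), so a change in which 12 heavy atoms leave and 9 enter, with 3 hydrogen-bond acceptors replaced by 0, still produces no readable difference. The smallest change in the series, fluoro in place of hydrogen on an aromatic carbon, gives a 1.0-fold lower number from compound 1 to compound 3 (0.01 log units; within the scatter), which is also within the scatter and adds a single-atom comparison to the two whole-group exchanges. Compound 1, compound 2 and compound 3 therefore cannot be ordered, and no information is available to explain this flat result.

The shown compounds all carry a substituted phenyl ring on this nitrogen, so it remains open whether any group here can move the number beyond the scatter. A plain phenyl, a phenyl bearing a carboxylic acid or an amine, or a longer alkyl chain in place of the ring would test this, and the same question stands for the tosyl group and the shared core.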